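A few compounds are considered here, and "the series" means these few. Any claim that something is new, unique, unknown or untested is made for them only; others in the source may bear on it.

Measured in an assay on cells for agonist activity at vitamin D3 receptor (Homo sapiens), with a stated time of 96 h; on this read-out higher numbers stand for an effect only at larger amounts of compound and lower numbers for an effect already at smaller amounts:
compound 1 `CCn1c(C(=O)NCCN)ccc1C(CC)(CC)c1ccc(OCCC(O)(CC)CC)c(C)c1` gives 156 nM.
compound 3 `CCOC(=O)C(CC(=O)OC)NC(=O)c1ccc(C(CC)(CC)c2ccc(OCCC(O)(CC)CC)c(C)c2)n1CC` gives 21 nM.
compound 2 `CCn1c(C(=O)Nc2ccc(OC(F)(F)F)cc2)ccc1C(CC)(CC)c1ccc(OCCC(O)(CC)CC)c(C)c1` gives > 10000 nM, which is a limit of the assay and not a number.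

Compound 2 thus stands at the limit of > 10000 nM in this assay, at which 1 of the 3 values shown sits, the top of the range shown. Compound 4 `CCC(C)C(CO)NC(=O)c1ccc(C(CC)(CC)c2ccc(OCCC(O)(CC)CC)c(C)c2)n1CC` differs from it by 1-(hydroxymethyl)-2-methylbutyl in place of 4-(trifluoromethoxy)phenyl on an amide-type nitrogen. Among the compounds with values here, two measured steps bear on this change, both exchanging a group with one six-membered aromatic ring of carbon only for a group with no ring on the amide-type nitrogen, or the reverse: an at least 64-fold higher number from compound 1 to compound 2 (1.80 log units; beyond the scatter) and an at least 470-fold lower number from compound 2 to compound 3 (2.67 log units; beyond the scatter). Both are large, and the change to compound 4 runs in the same direction as the step to compound 3. A large fall in the number is therefore expected, an at least 160-fold lower number from compound 2 to compound 4 (2.22 log units; beyond the scatter), given an at least 470-fold lower number from compound 2 to compound 3 (2.67 log units; beyond the scatter). Compound 4 is estimated at 60 nM, expected between 10 nM and 500 nM.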

Compound 4, half-maximal effective concentration: 450 nM
For compound 4 the middle estimate is 7.5-fold (0.88 log units) below the measured one; the range from low to high includes it.
By their numbers in this assay, from the lowest: compound 3; then compound 1; then compound 4. At a limit, above all of these: compound 2.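

Compound 2 stands at a limit of the assay, not at a number: the limit of > 10000 nM in this assay, at which 1 of the 4 values shown sits.

Against it, 1-(hydroxymethyl)-2-methylbutyl on the amide-type nitrogen still brings an at least 22-fold lower number from compound 2 to compound 4 (1.34 log units; beyond the scatter) in this assay, so a third group without a ring also clears that limit. The ring-free groups nevertheless differ among themselves: a 21-fold higher number from compound 3 to compound 4 (1.33 log units; beyond the scatter), and a 2.9-fold higher number from compound 1 to compound 4 (0.46 log units; beyond the scatter).

Still open, from the compounds shown here alone, is whether the hydroxymethyl or the branching of the new group sets its place in this order. A free carboxylic acid or an unbranched alkyl chain on the same nitrogen could fall near either compound 3 or compound 4.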